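Nitro in Place of Fluoro on the Pendant Phenyl

The compounds below may be only part of what the source reports. "The series", "measured", "known", "first", "only" and "open" are said of these compounds alone.

Of the compounds shown here, three built on one shared core have been measured in a functional assay on Huh-7 cells (Homo sapiens) for inhibition, read by sulforhodamine B assay, with a stated time of 72 h; a higher number here means a weaker inhibitor, a lower number a stronger inhibitor. Compound 1 `CC(c1ccc(-c2ccccc2)c(F)c1)c1nnc2n1N=C(c1ccc(Cl)cc1Cl)CS2` gives 3700 nM. Compound 2 `COc1ccc(C2=Nn3c(nnc3C(C)c3ccc(-c4ccccc4)c(F)c3)SC2)cc1` gives 4300 nM. Compound 3 `CC(c1ccc(-c2ccccc2)c(F)c1)c1nnc2n1N=C(c1ccc(F)cc1)CS2` gives 4900 nM, the highest of the three numbers, although its distance to each of the others lies within the scatter: a 1.3-fold higher number from compound 1 to compound 3 (0.12 log units; within the scatter) and a 1.1-fold higher number from compound 2 to compound 3 (0.06 log units; within the scatter), and between the other two a 1.2-fold higher number from compound 1 to compound 2 (0.07 log units; within the scatter). Compound 4 `CC(c1ccc(-c2ccccc2)c(F)c1)c1nnc2n1N=C(c1ccc([N+](=O)[O-])cc1)CS2` differs from compound 3 by nitro in place of fluoro on an aromatic carbon. The measured steps that bear on this change are the exchanges of the aryl group on the carbon with a double bond to nitrogen, and none of them moved this assay beyond the scatter. On that basis compound 4 is expected to show no step beyond the scatter, a 1.1-fold lower number from compound 3 to compound 4 (0.04 log units; within the scatter). For compound 4 in this assay the estimate is 4500 nM, with a range from 2000 nM to 10000 nM.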

Compound 4, half-maximal inhibitory concentration: 4300 nM
Compound 4: the middle estimate sits 1.0-fold (0.02 log units) above what was measured, within the range that was stated.
By their numbers in this assay, from the lowest: compounds 1, 2, 4 and 3 (each within the scatter of the next).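

In this assay the 4-nitrophenyl group stays within the scatter of all three aryl groups measured earlier on this carbon: a 1.1-fold lower number from compound 3 to compound 4 (0.06 log units; within the scatter) and no change at the digits printed from compound 2 to compound 4 (within the scatter) and a 1.2-fold higher number from compound 1 to compound 4 (0.07 log units; within the scatter) are the steps. Nitro brings 3 heavy atoms and 2 hydrogen-bond acceptors where fluoro brings 1 heavy atom and 0 acceptors, so the series now shows that this larger count at the place para to a large group goes with no step beyond the scatter. The data shown offer no measurement that would explain this flat result.

As far as these compounds go, it remains open whether an amine, a carboxylic acid or a longer alkyl chain on this aromatic carbon would also stay within the scatter. From the compounds shown here alone, all four compounds share the rest of their structure, so the effect of an exchange elsewhere remains open too.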